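This account rests on a few compounds, and the source may have more. Where it says the series, first, only, none or still open, it means among the compounds named here.

Of the compounds shown here, three from one series have been tested in an assay on HEK293 cells for displacement of a labelled ligand from 5-hydroxytryptamine receptor 6 (Homo sapiens), with a stated time of 60 min, tested at 0.01 uM, in the presence of a further agent that is not named here; a higher number here means a stronger effect of the compound at the concentration tested, a lower number a weaker effect. Compound 1, with structure `COc1cc(N)c(Cl)cc1C(=O)CCC1CCN(CCNS(=O)(=O)c2ccc(N)cc2)CC1`, carries a 4-aminophenyl group on the sulfonyl sulfur; in this assay compound 1 gives 7%. Compound 2, with structure `COc1cc(N)c(Cl)cc1C(=O)CCC1CCN(CCNS(=O)(=O)c2ccc(C)cc2)CC1`, has a 4-methylphenyl group in that place; in this assay compound 2 is reported as "not active" (no number reported), with no number attached. Compound 3, with structure `COc1ccc(S(=O)(=O)NCCCN2CCC(CCC(=O)c3cc(Cl)c(N)cc3OC)CC2)cc1`, differs in its chain as well as in its sulfonyl substituent; in this assay compound 3 is likewise reported as "not active" (no number reported), again without a number. So compound 2 stands with compound 3 among the entries that carry no numerical read-out, and the one number available, that of compound 1, is small.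

The next compound, compound 4 with structure `COc1cc(N)c(Cl)cc1C(=O)CCC1CCN(CCNS(=O)(=O)c2cc(Br)ccc2Br)CC1`, differs from compound 2 in one place: 2,5-dibromophenyl in place of 4-methylphenyl on a sulfonyl sulfur. Among the compounds with values here, no measured pair in this set shows the effect of such a change, so nothing in the data points to a step beyond the usual scatter in either direction. Compound 4 is therefore expected to give roughly 5%, somewhere between -8% and 20%, with a real chance that the assay again reports no number at all.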

Compound 4, a percentage reported as inhibition, at one concentration (the size of the read-out at that concentration, not a potency): 16%
Compound 4: the middle estimate sits 11 percentage points below what was measured; the range from low to high includes it.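

In this assay compound 2 stands as "not active" (no number reported) while compound 4 gives 16% as a small number, so 2,5-dibromophenyl in place of 4-methylphenyl on a sulfonyl sulfur yields a numerical read-out where there was none, but no size of step can be read from that pair. Within the data shown here, the one comparison that can be read is a number 9 percentage points higher from compound 1 to compound 4 (within the scatter) and so separates 2,5-dibromophenyl from 4-aminophenyl at this position by no more than repeated measurements would. Nothing available explains either observation.

From the compounds shown here alone, what the two bromine atoms contribute remains open: a phenyl ring with a single bromine, or with one at only one of these two places, would show whether either alone accompanies a numerical read-out. Going by these compounds, it also remains open whether a quite different group on the sulfonyl sulfur, such as a phenyl ring bearing a carboxylic acid or a plain methyl group with no ring at all, would give a read-out clearly beyond that of compound 1 at the single concentration tested.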